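Chlorine Position Swap on the Imine Aryl Group

A few compounds are considered here, and "the series" means these few. Any claim that something is new, unique, unknown or untested is made for them only; others in the source may bear on it.

Measured so far:
compound 1 `Nc1sc2c(c1-c1nc3ccccc3s1)CCCC2`: 163 ug/mL
compound 2 `Nc1sc2c(c1-c1nc3cc(Cl)ccc3s1)CCC2`: 67.8 ug/mL
compound 3 `Clc1ccc(/C=N/c2sc3c(c2-c2nc4ccccc4s2)CCC3)cc1`: 431 ug/mL

In an ADME assay on HepG2 cells (Homo sapiens) for cytotoxicity, read by MTT assay, with a stated time of 72 h (a lower number here means that less compound is tolerated, a higher number that more compound is tolerated), compound 3 gives 431 ug/mL, the highest of the three numbers. The gap to compound 1 and the gap to compound 2 both lie beyond the usual scatter, so compound 3 is the best tolerated of the three on these readings.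

Compound 4 `Clc1ccccc1/C=N/c1sc2c(c1-c1nc3ccccc3s1)CCC2` differs from compound 3 only in the position of the chlorine on the imine aryl group: 2-chlorophenyl in place of 4-chlorophenyl on a carbon with a double bond to nitrogen. Among the compounds with values here, no pair among the measured compounds shows a change of this kind, so nothing here tells how a move of the chlorine around the ring shifts the read-out. The two compounds are built from the same atoms with the same groups attached to the same carbon, and the step from compound 3 to compound 4 in this assay is expected to be small, not beyond the scatter, with the direction open. Compound 4 is therefore expected to give 360 ug/mL, within 160 ug/mL to 800 ug/mL, meaning an expected step of a 1.2-fold lower number from compound 3 to compound 4 (0.08 log units; within the scatter).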

Compound 4, half-maximal cytotoxic concentration: 180 ug/mL
For compound 4 the middle estimate is 2.0-fold (0.30 log units) above the measured one; low and high end bracket the measured number.
By their numbers in this assay, from the lowest: compound 2; then compounds 1 and 4 (each within the scatter of the next); then compound 3.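

In this assay, the series now has its first step at a single place: 2-chlorophenyl in place of 4-chlorophenyl on a carbon with a double bond to nitrogen gives a 2.4-fold lower number from compound 3 to compound 4 (0.38 log units; beyond the scatter) and this lies beyond the scatter. The read-out at this position therefore depends on where the chlorine sits on the aryl ring, even though both compounds hold the same atoms. Nothing at hand accounts for the size or direction of this step.

Going by these compounds, it remains open whether this dependence is specific to chlorine, or whether a methoxy group or a fluorine moved in the same way would give a similar step. An unsubstituted phenyl group at this place would show how either chlorophenyl group compares with the ring alone.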